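Nitro to trifluoromethyl: working notes on compound 3

The source may report more compounds than this note shows. Statements on the series, on what has been measured and on what is new or still open speak of the compounds shown alone.

Among the compounds with values here, in a functional assay on QGY-7703 cells (Homo sapiens) for cytotoxicity, read by MTT assay, with a stated time of 24 h (a lower number here means a stronger inhibitor, a higher number a weaker inhibitor), compound 1 (`Cc1ccc(S(=O)(=O)N2C/C(=C\c3ccncc3)C(=O)/C(=C/c3ccccc3C(F)(F)F)C2)cc1`) gives 5090 nM and compound 2 (`O=C1/C(=C/c2ccncc2)CN(S(=O)(=O)c2ccc([N+](=O)[O-])cc2)C/C1=C\c1ccccc1C(F)(F)F`) gives 9730 nM as the only two numbers so far. These two values lie within the scatter of each other, so compound 2 holds no separate rank in the series.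

Compound 3 (`O=C1/C(=C/c2ccncc2)CN(S(=O)(=O)c2ccc(C(F)(F)F)cc2)C/C1=C\c1ccccc1C(F)(F)F`) keeps the rest of compound 2 and carries trifluoromethyl in place of nitro on an aromatic carbon, para to a large group (trifluoromethyl in place of nitro on an aromatic carbon). Within the data shown here, one measured step bears on this change: nitro in place of methyl on that same aromatic carbon gives a 1.9-fold higher number from compound 1 to compound 2 (0.28 log units; within the scatter) and so stays small. That is a single pair, and no trifluoromethyl at this carbon has been measured yet.

No step beyond the scatter is therefore expected in this assay and no direction is firmly expected either. The estimated step is a 1.4-fold lower number from compound 2 to compound 3 (0.14 log units; within the scatter) as a working figure. For compound 3 the expected value is 7000 nM within an estimated range of 3000 nM to 16000 nM for now.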

Compound 3, half-maximal inhibitory concentration: 4680 nM
The estimate for compound 3 lay 1.5-fold (0.17 log units) above the measured number, and the stated range covers the measured number.
By their numbers in this assay, from the lowest: compounds 3, 1 and 2 (each within the scatter of the next, the first and the last beyond it).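

In this assay, within the data shown here, the change from nitro to trifluoromethyl on this aromatic carbon, para to a large group, gives a 2.1-fold lower number from compound 2 to compound 3 (0.32 log units; beyond the scatter) and is the first step at this position to pass beyond the scatter, though only modestly. Trifluoromethyl in place of methyl on the same carbon gives a 1.1-fold lower number from compound 1 to compound 3 (0.04 log units; within the scatter) and so leaves those two groups unseparated, which means that nitro stands apart from trifluoromethyl but not from methyl, and the three compounds span only a narrow band of numbers. Nothing measured alongside these numbers offers an explanation for the step from nitro to trifluoromethyl.

The compounds shown leave open whether an amine, a carboxylic acid or a methoxy group on this carbon, or plain hydrogen, would stay within the same narrow band or move the number well outside it. All three compounds also share the rest of the structure, so they do not show how much the shared core contributes to the cytotoxicity seen here, or whether the small step from nitro to trifluoromethyl would recur on a different core.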